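Lactam Nitrogen Demethylation in a Potent Tridecyl Ester

The source may report more compounds than this note shows. Statements on the series, on what has been measured and on what is new or still open speak of the compounds shown alone.

Compound 3, `CCCCCCCCCCCCCOC(=O)[C@H]1CCC(NC(=O)[C@H](OC)[C@H](O)[C@@H](O)[C@H](O)/C=C/C(C)C)C(=O)N(C)C1`, gives 2.4 nM in a functional assay on MDA-MB-435 cells (Homo sapiens) for antiproliferative activity (on this read-out higher numbers stand for weaker inhibition and lower numbers for stronger inhibition), the lowest of the three numbers measured. Compound 1, `CO[C@@H](C(=O)NC1CCCCN(C)C1=O)[C@H](O)[C@@H](O)[C@H](O)/C=C/C(C)C`, gives 2900 nM, and compound 2, `CO[C@@H](C(=O)NC1CC[C@H](O)CN(C)C1=O)[C@H](O)[C@@H](O)[C@H](O)/C=C/C(C)C`, gives 2900 nM; both sit far above compound 3. For the measured compounds named here, the one step measured between neighbours, no change at the digits printed from compound 1 to compound 2 (within the scatter), concerns a different part of the molecule and says nothing about the amide-type nitrogen in the ring. Compound 4, `CCCCCCCCCCCCCOC(=O)[C@H]1CCC(NC(=O)[C@H](OC)[C@H](O)[C@@H](O)[C@H](O)/C=C/C(C)C)C(=O)NC1`, differs from compound 3 by hydrogen in place of methyl on an amide-type nitrogen in a ring. Going by the values given here, no measured step touches this nitrogen, so the size of the step is not anchored by the data. The values of compound 1 and compound 3 show only that the tridecyl ester carries the large gain. Going by these compounds, the methyl on the ring nitrogen is shared by every measured compound, and its removal is untested; a modest loss is expected rather than a large one. Compound 4 is therefore estimated at 6 nM, between 1.5 nM and 40 nM, an expected step of a 2.5-fold higher number from compound 3 to compound 4 (0.40 log units; beyond the scatter).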

Compound 4, half-maximal inhibitory concentration: 1 nM
Compound 4: middle estimate off by 6.0-fold (0.78 log units), on the high side, outside the stated range (below it).
By their numbers in this assay, from the lowest: compound 4; then compound 3; then compounds 1 and 2 (each within the scatter of the next).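

In this assay, the methyl on the amide-type nitrogen in the ring proves dispensable in this tridecyl ester: hydrogen in its place gives a 2.4-fold lower number from compound 3 to compound 4 (0.38 log units; beyond the scatter) and so moves toward stronger inhibition, by a modest step beyond the scatter. For the compounds shown here, this is the first measured change at this nitrogen, as compounds 1, 2 and 3 all carry the methyl, and it shows that this compound loses no inhibition when that single carbon goes. Nothing available bears on the reason for this step.

Going by these compounds, whether an ethyl group or a longer chain on this nitrogen would keep the inhibition remains open. Also open, on these data alone, is whether hydrogen in place of methyl would give a similar step in compound 1, which has no tridecyl ester.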